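The source may hold more compounds than are shown below. What is called first, only, known or untested is meant among the compounds shown, and "the series" means these compounds.

Measured in a functional assay on A549 cells (Homo sapiens) for antiproliferative activity, read by MTT assay, with a stated time of 48 h; a lower number here means a stronger inhibitor, a higher number a weaker inhibitor:
- compound 1 `c1ccc(-c2nn(-c3ccccc3)cc2-c2nc3ccccc3[nH]2)cc1`: 2710 nM
- compound 2 `Fc1ccc2[nH]c(-c3cn(-c4ccccc4)nc3-c3ccccc3)nc2c1`: 1720 nM
- compound 3 `Cc1ccc2[nH]c(-c3cn(-c4ccccc4)nc3-c3ccccc3)nc2c1`: 3610 nM

Compound 3 sits at the upper end of these numbers, level with compound 1 within the scatter: a 1.3-fold higher number from compound 1 to compound 3 (0.12 log units; within the scatter). Within the data shown here, the only step beyond the scatter is modest: a 2.1-fold higher number from compound 2 to compound 3 (0.32 log units; beyond the scatter). Compound 4 `COc1ccc2[nH]c(-c3cn(-c4ccccc4)nc3-c3ccccc3)nc2c1` carries methoxy in place of methyl on an aromatic carbon. Among the measured compounds shown here, no methoxy compound has been measured, so the guide is the small size of the other substituent steps, such as a 1.6-fold lower number from compound 1 to compound 2 (0.20 log units; within the scatter). The estimated step, a 1.3-fold lower number from compound 3 to compound 4 (0.11 log units; within the scatter), stays within the scatter, with no firm direction expected. For compound 4 the expected value is 2800 nM, with an estimated range of 1300 nM to 5500 nM.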

Compound 4, half-maximal inhibitory concentration: 1230 nM
For compound 4 the middle estimate is 2.3-fold (0.36 log units) above the measured one, and the stated range ends above it.
By their numbers in this assay, from the lowest: compounds 4, 2, 1 and 3 (each within the scatter of the next, the first and the last beyond it).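

Methoxy is the first group on this aromatic carbon to give a step from the unsubstituted compound that lies beyond the scatter in this assay, a 2.2-fold lower number from compound 1 to compound 4 (0.34 log units; beyond the scatter), where fluoro and methyl did not; the exchange for methyl is also modest but clear, a 2.9-fold lower number from compound 3 to compound 4 (0.47 log units; beyond the scatter). Methoxy and fluoro remain level, a 1.4-fold lower number from compound 2 to compound 4 (0.15 log units; within the scatter). No available measurement bears on the reason for these differences.

Open, going by these compounds, is whether an amine, a carboxylic acid or a longer alkoxy chain here would go beyond compound 4. Also open, on these data alone, is whether methoxy elsewhere on the shared core would give a similar step.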